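A few compounds are considered here, and "the series" means these few. Any claim that something is new, unique, unknown or untested is made for them only; others in the source may bear on it.

In an ADME assay on HepG2 cells (Homo sapiens) for cytotoxicity, read by luminescence, CellTiter-Glo and ATP content, with a stated time of 72 h (on this read-out higher numbers stand for an effect only at larger amounts of compound and lower numbers for an effect already at smaller amounts), compound 3 `COc1cccc(CNCCCNc2ccnc3cc(Cc4ccc(C#N)cc4)ccc23)c1O` gives 7150 nM, the highest of the three numbers recorded. Compound 1 `COc1cccc(CNCCCNc2ccnc3cc(Cc4cc(C)cc(C)c4)ccc23)c1O` gives 2680 nM in this assay, and compound 2 `COc1cccc(CNCCCNc2ccnc3cc(CCC(C)C)ccc23)c1O` gives 5390 nM. The step of a 2.7-fold higher number from compound 1 to compound 3 (0.43 log units; beyond the scatter) is the only one of the three that reaches beyond the scatter; the steps of a 2.0-fold higher number from compound 1 to compound 2 (0.30 log units; within the scatter) and a 1.3-fold higher number from compound 2 to compound 3 (0.12 log units; within the scatter) both stay within it.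

Compound 4 `COc1ccccc1Oc1ccc2c(NCCCNCc3cccc(OC)c3O)ccnc2c1` differs from compound 3 in one place: 2-methoxyphenoxy in place of 4-cyanobenzyl on an aromatic carbon. The new group sits on the same aromatic carbon of the shared core that carried the 4-cyanobenzyl, 3,5-dimethylphenylmethyl and isobutylmethyl groups of compounds 3, 1 and 2. Among the compounds with values here, the steps of a 2.7-fold higher number from compound 1 to compound 3 (0.43 log units; beyond the scatter) and a 1.3-fold higher number from compound 2 to compound 3 (0.12 log units; within the scatter) therefore bear on it, since they also exchange the group at that carbon, but none of the measured steps exchanges a benzyl for an aryl ether, so the direction is not anchored. Given that these three groups span only a modest range in this assay, compound 4 is expected to show a step of a 1.2-fold lower number from compound 3 to compound 4 (0.08 log units; within the scatter), that is, no change beyond the scatter. The number expected for compound 4 in this assay is 6000 nM, with a range from 2500 nM to 15000 nM.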

Compound 4, half-maximal effective concentration: 11200 nM
The estimate for compound 4 lay 1.9-fold (0.27 log units) below the measured number; measured number inside the range.
By their numbers in this assay, from the lowest: compounds 1, 2, 3 and 4 (each within the scatter of the next, the first and the last beyond it).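

In this assay, within the data shown here, the 2-methoxyphenoxy of compound 4 is the first group in this set joined to the aromatic carbon through oxygen rather than through a saturated carbon, and its exchange for 4-cyanobenzyl gives a 1.6-fold higher number from compound 3 to compound 4 (0.19 log units; within the scatter), so this change of group and link does not separate the two compounds. Measured against the other two groups at the same carbon, the 2-methoxyphenoxy does reach past the scatter, with a 2.1-fold higher number from compound 2 to compound 4 (0.32 log units; beyond the scatter) and a 4.2-fold higher number from compound 1 to compound 4 (0.62 log units; beyond the scatter), which widens the spread seen at this position, although the size of each step remains modest. Nothing available here explains these differences.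

The compounds shown leave open whether the number of compound 4 goes with the oxygen link, with the methoxy group on its ring, or with both, a question that a plain phenoxy or a 2-methoxybenzyl at this carbon would separate. Going by these compounds, it also remains open how far the numbers would move with a carboxylic acid or an amine at this position.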